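Adding a Second Chloro to a Benzyl-Substituted Core

The compounds below may be only part of what the source reports. "The series", "measured", "known", "first", "only" and "open" are said of these compounds alone.

Measured compounds:
- Compound 1 `ClCc1ccccc1Cn1cnc2nc(Cl)nc(Cl)c21`: 1250 nM
- Compound 2 `ClCc1ccccc1Cn1cnc2c(Cl)nc(Cl)nc21`: 1620 nM
- Compound 3 `ClCc1ccc(Cn2cnc3ncnc(Cl)c32)cc1`: "not determined" (no result reported)

Three compounds of this series were taken into a functional assay on ACHN cells (Homo sapiens) for cytotoxicity, read by sulforhodamine B assay, with a stated time of 48 h; on this read-out lower numbers stand for stronger inhibition of growth and higher numbers for weaker inhibition of growth. Compound 1 gives 1250 nM in this assay, and compound 2 gives 1620 nM; these two values lie within the usual scatter of each other, so they cannot be told apart. Compound 3 carries one chloro group on its core where compounds 1 and 2 carry two, and for compound 3 the result in this assay is "not determined" (no result reported), so there is no starting value to build on.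

Compound 4 `ClCc1ccc(Cn2cnc3nc(Cl)nc(Cl)c32)cc1` is the one still to be measured. Compared with compound 3 it differs by chloro in place of hydrogen on an aromatic carbon. For the measured compounds named here, with no value for compound 3, no step from it can be given, so the expectation for compound 4 rests on compounds 1 and 2 alone, which share the two-chloro core and both sit in the low micromolar range in this assay. Compound 4 is therefore expected to land near those two, at about 1500 nM, with a plausible range from 500 nM to 5000 nM.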

Compound 4, concentration for total growth inhibition: 3310 nM
Estimate against measurement, compound 4: 2.2-fold (0.34 log units) below; low and high end bracket the measured number.
By their numbers in this assay, from the lowest: compounds 1 and 2 (each within the scatter of the next); then compound 4.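

For the compounds shown here, compound 3 has no number in this assay, so no step from it to compound 4 can be read. The compounds shown leave open what chloro in place of hydrogen on this aromatic carbon does to growth inhibition. Nothing given here offers an explanation for the value of compound 4, 3310 nM.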